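A few compounds are considered here, and "the series" means these few. Any claim that something is new, unique, unknown or untested is made for them only; others in the source may bear on it.

Measured compounds:
compound 1, `Cc1ccccc1S(=O)(=O)c1ccc(CNC(=O)c2cc3cnccc3[nH]2)cc1`: 12 nM
compound 2, `O=C(NCc1ccc(S(=O)(=O)c2ccccc2)cc1)c1ccc2nccn2c1`: 18 nM

Among the compounds with values here, in an assay for inhibition of Nicotinamide phosphoribosyltransferase (Homo sapiens), read by mass spectrometry, with stated times of 15 min and 30 min (a lower number here means a stronger inhibitor, a higher number a weaker inhibitor), compound 1 gives 12 nM, the lower of the two numbers so far. Compound 2 gives 18 nM, and the gap between these two values lies within the usual scatter of the measurement, so neither can be called the more potent of the pair. Compound 3, `O=C(NCc1ccc(S(=O)(=O)c2ccccc2C(F)(F)F)cc1)c1cc2cnccc2[nH]1`, has not yet been measured. It differs from compound 1 in one place: trifluoromethyl in place of methyl on an aromatic carbon. Within the data shown here, no step between two measured compounds covers this change, so there is no direct precedent in this set to lean on. The expectation is that the step from compound 1 to compound 3 will be small, a 1.3-fold higher number from compound 1 to compound 3 (0.10 log units; within the scatter), not clearly beyond the scatter in either direction. Compound 3 is therefore estimated at 15 nM in this assay, with a range from 5 nM to 45 nM.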

Compound 3, half-maximal inhibitory concentration: 24 nM
Estimate against measurement, compound 3: 1.6-fold (0.20 log units) below; the measured number falls inside the stated range.
By their numbers in this assay, from the lowest: compounds 1, 2 and 3 (each within the scatter of the next).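

Replacing methyl with trifluoromethyl on an aromatic carbon of the six-membered ring, ortho to a large group, gives a 2.0-fold higher number from compound 1 to compound 3 (0.30 log units; within the scatter) in this assay. Within the data shown here, this is the first view of this position: a group of 4 heavy atoms can stand where a group of 1 heavy atom stood, and the number stays within the scatter of the measurement. No measurement here explains why these two groups read so alike.

On the core of compound 1, only methyl and trifluoromethyl are shown at this carbon, so it remains open how a plain hydrogen would read there. On these data alone, it also remains open whether an amine, a carboxylic acid or a longer chain at the same carbon would keep the number in this range.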